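Phenethyl for Cyclohexyl on a Sulfur-Bound Chain

The source may report more compounds than this note shows. Statements on the series, on what has been measured and on what is new or still open speak of the compounds shown alone.

Of the compounds shown here, three have been measured in a functional assay on MCF7 cells (Homo sapiens) for inhibition, read by MTT assay, with a stated time of 72 h; on this read-out higher numbers stand for weaker inhibition and lower numbers for stronger inhibition. Compound 1 `Cc1cc(Nc2ccn(Cc3cccc4ccccc34)n2)n2nc(SCc3ccc(Br)cc3)nc2n1` gives 4310 nM. Compound 3 `CCCCCc1c(C)nc2nc(SCc3ccc(Cl)cc3)nn2c1Nc1cc(-c2ccccc2)[nH]n1` gives 6390 nM. Compound 2 `Cc1cc(Nc2cc(-c3ccccc3)[nH]n2)n2nc(SCC3CCCCC3)nc2n1` returns only a limit, > 50000 nM. On these data alone, it stands at the limit of > 50000 nM in this assay, at which 1 of the 3 values shown sits, so its true position on the scale is unknown.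

Compound 4 `Cc1cc(Nc2cc(-c3ccccc3)[nH]n2)n2nc(SCCCc3ccccc3)nc2n1` keeps the shared core of compound 2 and alters a single place: phenethyl in place of cyclohexyl on a saturated chain carbon bound to a sulfur. Phenethyl replaces cyclohexyl on a saturated chain carbon bound to a sulfur, which also reads as cyclohexylmethyl to 3-phenylpropyl.

Among the measured compounds shown here, no measured pair isolates this change, so any expectation rests on indirect evidence. The two numerical results, compound 1 at 4310 nM and compound 3 at 6390 nM, both come from compounds with an aromatic ring on the sulfur side, which compound 2 lacks. A moderate move toward stronger inhibition is therefore expected in this assay, although a second limit remains possible. The expected step is an at least 2.5-fold lower number from compound 2 to compound 4 (0.39 log units; beyond the scatter). For compound 4, the estimated value is 20000 nM, with an expected range of 7000 nM to 50000 nM.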

Compound 4, half-maximal inhibitory concentration: 3900 nM
Beside the measured number, compound 4's estimate is 5.1-fold (0.71 log units) above it; measured number below the stated range.
By their numbers in this assay, from the lowest: compounds 4, 1 and 3 (each within the scatter of the next). At a limit, above all of these: compound 2.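

Among the compounds shown here, with the shared core held fixed, this is the first change confined to one place, and it shows that the sulfur-bound group alone can decide whether a measurable number appears in this assay. Phenethyl in place of cyclohexyl on a saturated chain carbon bound to a sulfur gives an at least 12-fold lower number from compound 2 to compound 4 (1.10 log units; beyond the scatter), a large step. Its full size cannot be read, as compound 2 is only a limit: the limit of > 50000 nM in this assay, at which 1 of the 4 values shown sits.

The compounds shown leave open which part of the change carries the step, as the ring turns aromatic and the chain between ring and sulfur grows longer in the same exchange. On these data alone, a cyclohexylethyl group on the sulfur would separate these two, and how it would compare with phenethyl remains unknown.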